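The source may report more compounds than this note shows. Statements on the series, on what has been measured and on what is new or still open speak of the compounds shown alone.

In a functional assay on HO8910 cells (Homo sapiens) for inhibition, read by MTT assay, with a stated time of 24 h, tested at 100 ug/mL; a higher number here means more inhibition of growth at the concentration tested, a lower number less inhibition of growth:
- compound 1 `O=C(CCCCC(S)CCS)NO`: 49.3%
- compound 2 `O=C(CCCCC1CCSS1)Nc1ccccn1`: 51.9%
- compound 3 `O=C(CCCCC(S)CCS)Nc1ccccc1`: 13.7%

Compound 3 stands lowest of the three. Compound 4 `O=C(CCCCC(S)CCS)Nc1ccccn1` differs from it by a single change, pyridin-2-yl in place of phenyl on an amide-type nitrogen. Among the measured compounds shown here, no measured step covers this exact change. The closest is a number 35.6 percentage points lower from compound 1 to compound 3 (beyond the scatter), a large step at the same kind of nitrogen. Compound 2 carries the same pyridin-2-yl but differs from compound 4 elsewhere, so compound 2 at 51.9% is only a loose guide. A rise smaller than that large step is therefore expected in this assay, probably beyond the scatter. The expected change is a number 16.3 percentage points higher from compound 3 to compound 4 (beyond the scatter). Compound 4 is estimated at 30%, with an expected range of 14% to 52%.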

Compound 4, percent growth inhibition at one concentration: 14.2%
The estimate for compound 4 lay 15.8 percentage points above the measured number; measured number inside the range.
By their numbers in this assay, from the lowest: compounds 3 and 4 (each within the scatter of the next); then compounds 1 and 2 (each within the scatter of the next).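

Pyridin-2-yl in place of phenyl on the amide-type nitrogen gives, in this assay, a number 0.5 percentage points higher from compound 3 to compound 4 (within the scatter), so this change does not separate the two compounds. Pyridin-2-yl in place of hydroxy gives a number 35.1 percentage points lower from compound 1 to compound 4 (beyond the scatter), much like the earlier phenyl step. The open group in place of the five-membered ring with 2 hetero atoms gives a number 37.7 percentage points lower from compound 2 to compound 4 (beyond the scatter), so the number of compound 2 cannot be credited to pyridin-2-yl alone.

Nothing available explains these steps. Going by these compounds, how a pyridin-3-yl group or a methoxy group on that nitrogen would read remains open.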